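The source may hold more compounds than are shown below. What is called first, only, known or untested is meant among the compounds shown, and "the series" means these compounds.

Compound 1, `COc1ncc(C(F)(F)F)cc1CO[C@H]1[C@H](C(C)(C)C)[C@@H](C(=O)O)N(C(=O)[C@@H]2CCCCO2)[C@H]1c1ccccc1`: in an assay on cells with Cystic fibrosis transmembrane conductance regulator variant F508del (Homo sapiens) as the target, read by voltage clamp, with a stated time of 24 h, in the presence of a further agent that is not named here (a higher number here means a larger maximal response, a lower number a smaller maximal response), compound 1 gives 720%.
Compound 2, `COc1ncc(C(F)(F)F)cc1CO[C@H]1[C@H](C(C)(C)C)[C@@H](C(=O)O)N(C(=O)[C@@H]2CCCCO2)[C@H]1c1ccccc1C(C)C`: compound 2 gives 570%.
Compound 3, `COc1ncc(C(F)(F)F)cc1CO[C@H]1[C@H](C(C)(C)C)[C@@H](C(=O)O)N(C(=O)[C@@H]2CCCCO2)[C@H]1c1ccccc1C1CC1`: compound 3 gives 610%.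

Among these three numbers compound 3 stands second highest, with compound 2 below it and compound 1 above it, both gaps beyond the scatter, as the steps of a number 40 percentage points higher from compound 2 to compound 3 (beyond the scatter) and a number 110 percentage points lower from compound 1 to compound 3 (beyond the scatter) show. Compound 4, `COc1ncc(C(F)(F)F)cc1CO[C@H]1[C@H](C(C)(C)C)[C@@H](C(=O)O)N(C(=O)[C@@H]2CCCCO2)[C@H]1c1ccccc1Cl`, is not yet measured. It differs from compound 3 in one place: chloro in place of cyclopropyl on an aromatic carbon. Among the compounds with values here, two measured steps bear on this change. Entry of a cyclopropyl gave a number 110 percentage points lower from compound 1 to compound 3 (beyond the scatter), and entry of an isopropyl gave a number 150 percentage points lower from compound 1 to compound 2 (beyond the scatter). Within the data shown here, the chloro entering here counts fewer heavy atoms than either of those groups, and no measured compound carries a chloro there, so the direction rests on this comparison alone. A modest rise from compound 3 toward the value of compound 1 is expected, a number 40 percentage points higher from compound 3 to compound 4 (beyond the scatter), though a number within the scatter of compound 3 would not be surprising. Compound 4 is therefore estimated at 650%, with a likely range from 560% to 760%.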

Compound 4, largest response reached (Emax), in percent of the reference or control that the assay uses: 694%
For compound 4 the middle estimate is 44 percentage points below the measured one; the range from low to high includes it.
By their numbers in this assay, from the lowest: compound 2; then compound 3; then compound 4; then compound 1.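

In this assay, within the data shown here, the earlier compounds showed only that a group at this aromatic carbon lowers the number, but the choice of group turns out to matter a great deal: chloro in place of cyclopropyl gives a number 84 percentage points higher from compound 3 to compound 4 (beyond the scatter) and chloro in place of isopropyl gives a number 124 percentage points higher from compound 2 to compound 4 (beyond the scatter). Hydrogen still holds the top place, with a number 26 percentage points lower from compound 1 to compound 4 (beyond the scatter) for chloro in place of hydrogen, so all three groups shown give a lower number than hydrogen, yet chloro, with its single heavy atom, costs far less than either carbon group. Chloro differs from those groups in more than its count of heavy atoms, and nothing measured here accounts for the gap between them.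

As far as these compounds go, it remains open whether fluoro or methyl at this place would land closer to compound 1 or closer to compound 3, and so whether the loss follows the size of the group or the kind of atom attached to the ring. Also open is how chloro or methoxy would behave on another carbon of the same ring, since every substituted compound shown carries its group at this one place.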